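The compounds below may be only part of what the source reports. "The series", "measured", "known", "first", "only" and "open" are said of these compounds alone.

Measured compounds:
- compound 1, `Cc1nc[nH]c1CN[C@@H]1C[C@@H]2C[C@H]([C@H]1C)C2(C)C`: in an ADME assay on MDCK cells (Canis lupus familiaris) for cytotoxicity, read by MTT assay, with a stated time of 48 h (on this read-out higher numbers stand for lower toxicity in this test and lower numbers for higher toxicity in this test), compound 1 gives 252000 nM
- compound 2, `C[C@@H]1[C@H]2C[C@@H](C[C@H]1NCc1[nH]cnc1C(C)(C)C)C2(C)C`: in this assay compound 2 gives 72300 nM

Compound 1 stands highest of the two numbers, meaning the lowest toxicity of the two; its nearest neighbour is compound 2, which lies a 3.5-fold lower number from compound 1 to compound 2 (0.54 log units; beyond the scatter).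

Compound 3, `C[C@@H]1[C@H]2C[C@@H](C[C@H]1NCc1[nH]cnc1-c1ccccc1)C2(C)C`, is not yet measured. It differs from compound 1 in one place: phenyl in place of methyl on an aromatic carbon. In both compounds the shared core and the amine linker stay the same; only the group on that aromatic carbon grows.

Within the data shown here, the one measured step that bears on this change is the one from compound 1 to compound 2, where a tert-butyl replaced the same methyl and gave a 3.5-fold lower number from compound 1 to compound 2 (0.54 log units; beyond the scatter). Replacing the methyl with a phenyl is a comparable growth at the same place, so a step of similar size in the same direction is expected, that is a lower number and somewhat higher toxicity.

Compound 3 is therefore expected to give about 80000 nM, within 30000 nM to 200000 nM, which means an estimated step of a 3.2-fold lower number from compound 1 to compound 3 (0.50 log units; beyond the scatter).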

Compound 3, half-maximal cytotoxic concentration: 39700 nM
Compound 3: the middle estimate sits 2.0-fold (0.30 log units) above what was measured; low and high end bracket the measured number.
By their numbers in this assay, from the lowest: compounds 3 and 2 (each within the scatter of the next); then compound 1.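

In this assay the aromatic carbon now has a second replacement for methyl to compare: the step of a 6.3-fold lower number from compound 1 to compound 3 (0.80 log units; beyond the scatter) runs in the same direction as the step of a 3.5-fold lower number from compound 1 to compound 2 (0.54 log units; beyond the scatter) and so, among these three compounds, both larger groups give a lower number, which stands for higher toxicity in this test. Phenyl and tert-butyl cannot be told apart at this position, since the step of a 1.8-fold lower number from compound 2 to compound 3 (0.26 log units; within the scatter) means that a six-membered aromatic ring and a tert-butyl group leave the read-out in the same range. Nothing available explains why either replacement lowers the number.

What a hydrogen or an ethyl group on this carbon would give stays open, so the compounds shown do not tell how large a group can become before the number leaves the range of compound 1. Also open, going by these compounds, is whether a ring containing nitrogen, such as pyridyl, or a phenyl carrying a hydroxyl group would give a number like that of compound 3 or one closer to that of compound 1.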